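The source may report more compounds than this note shows. Statements on the series, on what has been measured and on what is new or still open speak of the compounds shown alone.

Measured compounds in an assay on isolated protein for inhibition of Aromatase (Homo sapiens), read by fluorescence, using NADPH, with a stated time of 30 min, tested at 50 uM; a higher number here means more inhibition at the concentration tested (going by the name of the read-out), a lower number less inhibition:
compound 1 `Cc1ccc(-c2cc3ccccc3[nH]2)cc1`: 9.33%
compound 2 `CCCCCc1ccc(-c2cc3ccccc3[nH]2)cc1`: 0%
compound 3 `Cc1ccccc1-c1cc2ccccc2[nH]1`: 27.1%

Compound 2 gives the lowest of the three numbers in this assay, but its gap to compound 1 lies within the usual scatter, so the two cannot be told apart; only compound 3 stands beyond the scatter above compound 2.

Compound 4 `CN(C)c1ccc(-c2cc3ccccc3[nH]2)cc1` has not been measured. Relative to compound 2 the change is dimethylamino in place of pentyl on an aromatic carbon.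

For the measured compounds named here, the one measured step at the same place is a number 9.3 percentage points lower from compound 1 to compound 2 (within the scatter), where butyl in place of hydrogen on the chain left the number within the scatter. Going by the values given here, no measured step exchanges a chain for dimethylamino, and no measured compound carries dimethylamino at all, so the step to compound 4 is not covered by a close analogy and rests on weak ground. Among the compounds with values here, since the only step touching this position stays within the scatter, no step beyond the scatter is expected in this assay; compound 4 is expected to sit near compound 2 and compound 1, the estimated step being a number 10 percentage points higher from compound 2 to compound 4 (within the scatter).

Estimate for compound 4 in this assay: 10%, with a range from 0% to 30%.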

Compound 4, a percentage reported as inhibition, at one concentration (the size of the read-out at that concentration, not a potency): 0%
The estimate for compound 4 lay 10 percentage points above the measured number, within the range that was stated.
By their numbers in this assay, from the lowest: compounds 2, 4 and 1 (each within the scatter of the next); then compound 3.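

Within this assay, the exchange of pentyl for dimethylamino on the aromatic carbon gives no change at the digits printed from compound 2 to compound 4 (within the scatter), and the exchange of methyl for dimethylamino at the same place gives a number 9.3 percentage points lower from compound 1 to compound 4 (within the scatter). For the compounds shown here, this position has so far been seen only with saturated chains, and the first group there to carry a nitrogen does not separate from either of them: compound 1, compound 2 and compound 4 cannot be told apart in this read-out, so neither chain length nor the entry of that nitrogen registers as a step beyond the scatter. No accompanying measurement bears on why these three numbers stay together.

Still open, on these data alone, is whether any group at this position can lift the number clear of the scatter, for instance a carboxylic acid, a primary amine or a longer chain ending in a hydroxyl group. Going by these compounds alone, also open is whether dimethylamino in place of the methyl of compound 3, the one compound standing clear of compound 2 and compound 4, would hold the number of compound 3 at 27.1% or bring it back among the others.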